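A few compounds are considered here, and "the series" means these few. Any claim that something is new, unique, unknown or untested is made for them only; others in the source may bear on it.

Compound 2 `Cc1ccccc1CC1(C)CC(S(=O)(=O)c2ccc(F)cc2)=C(c2ccc(/C(N)=N/O)cc2)O1` gives the highest of the two numbers recorded so far in an ADME assay on cells (Peritoneal macrophage, Mus musculus, strain Balb/c) for cytotoxicity, read by resazurin assay, with a stated time of 72 h (a higher number here means that more compound is tolerated, a lower number that less compound is tolerated), namely 77600 nM. Going by the values given here, its only measured neighbour, compound 1 `CC1(Cc2cccc(/C(N)=N/O)c2)CC(S(=O)(=O)c2ccc(F)cc2)=C(c2ccc(/C(N)=N/O)cc2)O1`, gives 50200 nM in this assay, and the step of a 1.5-fold higher number from compound 1 to compound 2 (0.19 log units; within the scatter) is the single comparison available. That step also exchanged the group attached to the saturated ring carbon of the shared core, and the tolerated concentration barely moved.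

Compound 3 `CC1(/C=C/c2ccc(C(F)(F)F)cc2)CC(S(=O)(=O)c2ccc(F)cc2)=C(c2ccc(/C(N)=N/O)cc2)O1` differs from compound 2 by 2-(4-(trifluoromethyl)phenyl)ethenyl in place of 2-methylbenzyl on a saturated ring carbon, again at that same ring carbon. Among the compounds with values here, the one step that bears on such a change, from compound 1 to compound 2, stayed within the scatter, so no movement beyond the scatter is expected here either. The step of a 1.2-fold lower number from compound 2 to compound 3 (0.08 log units; within the scatter) is therefore estimated to be small. Compound 3 is expected to give about 65000 nM in this assay, with a likely range from 25000 nM to 170000 nM.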

Compound 3, half-maximal cytotoxic concentration: 43900 nM
For compound 3 the middle estimate is 1.5-fold (0.17 log units) above the measured one; the measured number falls inside the stated range.
By their numbers in this assay, from the lowest: compounds 3, 1 and 2 (each within the scatter of the next).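

At the saturated ring carbon next to the ring oxygen, a group with a double bond outside the aromatic ring and three fluorine atoms is accommodated within the scatter of this assay, with 2-(4-(trifluoromethyl)phenyl)ethenyl in place of 2-methylbenzyl giving a 1.8-fold lower number from compound 2 to compound 3 (0.25 log units; within the scatter), and the comparison with the group of compound 1, which carries nitrogen and oxygen, giving a 1.1-fold lower number from compound 1 to compound 3 (0.06 log units; within the scatter). Across these three compounds, then, the tolerated concentration does not separate beyond the scatter, even though the groups at this position differ in size and in their atoms. No available evidence bears on these numbers.

All three groups contain a six-membered aromatic ring of carbon only, so these compounds leave open what a plain alkyl chain would do here. They also leave open whether an amine or a carboxylic acid at this position would move the number beyond the scatter.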